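A few compounds are considered here, and "the series" means these few. Any claim that something is new, unique, unknown or untested is made for them only; others in the source may bear on it.

In a functional assay on SK-BR-3 cells (Homo sapiens) for antiproliferative activity, read by MTT assay, with a stated time of 72 h (on this read-out higher numbers stand for weaker inhibition and lower numbers for stronger inhibition), compound 1 (`C/C=C1/[C@H](O[C@@H]2O[C@H](CO)[C@@H](O)[C@H](O)[C@H]2O)OC=C(C(=O)OC)[C@H]1CC(=O)NCCC`) gives > 20000 nM as a limit, not a number. Compound 2 (`C/C=C1/[C@H](O[C@@H]2O[C@H](COC(C)=O)[C@@H](OC(C)=O)[C@H](OC(C)=O)[C@H]2OC(C)=O)OC=C(C(=O)OC)[C@H]1CC(=O)OCCC1CCCCC1`) gives > 15000 nM as a limit. Compound 3 (`C/C=C1/[C@H](O[C@@H]2O[C@H](COC(C)=O)[C@@H](OC(C)=O)[C@H](OC(C)=O)[C@H]2OC(C)=O)OC=C(C(=O)OC)[C@H]1CC(=O)OCCC(C)C`) gives > 15000 nM as a limit too. Among the measured compounds shown here, every value so far is thus a limit (the limit of > 15000 nM in this assay, at which 2 of the 3 values shown sit; (the limit of > 20000 nM in this assay, at which 1 of the 3 values shown sits)), and compound 1 has no measured number to stand on.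

Compound 4 (`C/C=C1/[C@H](O[C@@H]2O[C@H](CO)[C@@H](O)[C@H](O)[C@H]2O)OC=C(C(=O)OC)[C@H]1CC(=O)OCCC`) differs from compound 1 by a single change (propoxy in place of propylamino on a carbonyl carbon): propoxy in place of propylamino on a carbonyl carbon. For the measured compounds named here, the only measured step (a step that the two limits leave unreadable from compound 2 to compound 3) cannot be read for size and concerns a different change. Compound 2 and compound 3 carry an oxygen on that carbonyl carbon, but they differ from compound 4 elsewhere as well, and their limits give no size for this change.

No shift beyond the scatter, in either direction, is therefore expected in this assay (a number no higher from compound 1 to compound 4 (the limit leaves the size open)). The expectation rests on compound 1, whose value > 20000 nM is a limit. For compound 4 the estimated value is 20000 nM in an expected range from 10000 nM to 40000 nM and a report as a limit is likely.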

Compound 4, half-maximal inhibitory concentration: > 15000 nM
Compound 4: no number, only a limit (the forecaster's own chance of this, stated with the estimate: 85%); the middle value does not contradict the limit.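

Compound 1 and compound 4 are both reported only as limits, so the change to propoxy in place of propylamino on a carbonyl carbon gives no readable step. The compounds shown leave open whether this change has any effect on potency, and of what size.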